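Moving the Fluorine on the Sulfonyl Aryl Ring

A few compounds are considered here, and "the series" means these few. Any claim that something is new, unique, unknown or untested is made for them only; others in the source may bear on it.

Compound 1 `NCCn1cc(S(=O)(=O)c2cccc(F)c2)c2cccnc21` carries a primary amine at the end of its side chain. In an assay on HeLa cells for displacement of a labelled ligand from 5-hydroxytryptamine receptor 6 (Homo sapiens) (on this read-out lower numbers stand for stronger inhibition and higher numbers for weaker inhibition), compound 1 gives 4.7 nM, the lowest of the two numbers measured. Compound 2 `O=S(=O)(c1cccc(F)c1)c1cn(CCN2CCCC2)c2ncccc12` gives 88 nM, and the step of a 19-fold higher number from compound 1 to compound 2 (1.27 log units; beyond the scatter) shows how much a pyrrolidin-1-yl group in place of the amino group costs.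

Compound 3 `NCCn1cc(S(=O)(=O)c2ccc(F)cc2)c2cccnc21` keeps the amine chain and the shared core of compound 1 and differs only on the sulfonyl sulfur: 4-fluorophenyl in place of 3-fluorophenyl on a sulfonyl sulfur. For the measured compounds named here, the single measured step concerns the amine end of the molecule, not the fluorinated ring, so it does not bear on this change. No comparison of this kind is available. The expectation for compound 3 is that the step of a 1.3-fold higher number from compound 1 to compound 3 (0.11 log units; within the scatter) stays within the scatter, in either direction. Compound 3 is therefore estimated at 6 nM, with a range of 2 nM to 20 nM.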

Compound 3, inhibition constant: 22 nM
Beside the measured number, compound 3's estimate is 3.7-fold (0.56 log units) below it; measured number above the stated range.
By their numbers in this assay, from the lowest: compound 1; then compound 3; then compound 2.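

Moving the fluorine is not a neutral change at this position. In this assay, 4-fluorophenyl in place of 3-fluorophenyl on a sulfonyl sulfur gives a 4.7-fold higher number from compound 1 to compound 3 (0.67 log units; beyond the scatter) even though the two groups have the same atoms, joined differently, so the read-out responds to the arrangement of the ring as well as to the amine end of the side chain. No measurement available here explains why the 3-fluorophenyl compound gives the lower number.

The compounds shown leave open whether the fluorine itself contributes to the lower number of compound 1, which a plain phenyl group at the same place would help to settle. They also leave open whether another halogen, as in 3-chlorophenyl, would give a number closer to that of compound 1 or to that of compound 3.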